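This account rests on a few compounds, and the source may have more. Where it says the series, first, only, none or still open, it means among the compounds named here.

Measured compounds:
- compound 1 `CCCCCCCCC(C)(C)C(=O)Nc1c(C)cc(C)c2c1OC(C)(C)C2`: 140 nM
- compound 2 `CCCCCCCCCCCCC(C)(C)C(=O)Nc1c(C)cc(C)c2c1OC(C)(C)C2`: 33 nM

In an assay for inhibition of acyl-CoA:cholesterol acyltransferase (Oryctolagus cuniculus), using microsomes (a lower number here means a stronger inhibitor, a higher number a weaker inhibitor), compound 1 gives 140 nM, the highest of the two numbers at hand; its nearest neighbour is compound 2, which gives 33 nM in this assay. Going by the values given here, the single measured step, a 4.2-fold lower number from compound 1 to compound 2 (0.63 log units; beyond the scatter), shows that lengthening the saturated chain at its far end lowers the number by a modest amount that lies beyond the scatter.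

Compound 3 `Cc1cc(C)c(NC(=O)C(C)(C)CCCCOc2ccc(Cl)cc2)c2c1CC(C)(C)O2` is not yet measured. It differs from compound 1 by 4-chlorophenoxy in place of butyl on a saturated chain carbon, five bonds along the chain from a carbonyl carbon. Among the compounds with values here, no measured step covers this exchange directly; the only guidance is that the step from compound 1 to compound 2 rewards more bulk at the chain end, and compound 3 also carries more bulk there, though of a different kind. Compound 3 is therefore expected to sit somewhat below compound 1 in this assay, a step of roughly a 1.8-fold lower number from compound 1 to compound 3 (0.24 log units; within the scatter), with an estimate of 80 nM and a range from 25 nM to 300 nM.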

Compound 3, half-maximal inhibitory concentration: 330 nM
Compound 3: middle estimate off by 4.1-fold (0.62 log units), on the low side; the whole stated range lies below it.
By their numbers in this assay, from the lowest: compound 2; then compound 1; then compound 3.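

In this assay, a larger group at this place, on a saturated chain carbon five bonds along the chain from a carbonyl carbon, does not by itself lower the number: exchanging butyl for 4-chlorophenoxy gives a 2.4-fold higher number from compound 1 to compound 3 (0.37 log units; beyond the scatter) even though more heavy atoms enter than leave. Set against octyl, the same group gives a 10-fold higher number from compound 2 to compound 3 (1.00 log units; beyond the scatter) and so falls well short of the longer saturated chain, which shows that the kind of group at the chain end matters as well as its size. No measurement at hand explains why the ring-bearing group behaves differently from the saturated chains.

The aromatic ring, the oxygen and the chlorine all enter together, so the compounds shown cannot say which of them goes with the higher number. Plain phenoxy, or phenyl without the oxygen, would separate these parts, and how an amine or a carboxylic acid at the chain end would behave also remains open.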